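Furan-2-yl in Place of 4-Methoxyphenyl: An Expected Read-Out

The compounds below may be only part of what the source reports. "The series", "measured", "known", "first", "only" and "open" are said of these compounds alone.

Measured so far in a functional assay on the whole organism (strain albino) for inhibition, with Rattus norvegicus as the target, read by paw edema, with stated times of 30 min and 5 h, at a dose of 100 mg/kg by the oral route; a higher number here means more inhibition at the dose given (going by the name of the read-out), a lower number less inhibition:
Compound 1, `O=C(COCc1c(-c2ccccc2)no[n+]1[O-])Nc1ccc(C(=O)/C=C/c2ccc(Cl)cc2)cc1`: 62%
Compound 2, `COc1ccc(/C=C/C(=O)c2ccc(NC(=O)COCc3c(-c4ccccc4)no[n+]3[O-])cc2)cc1`: 49%

Going by the values given here, compound 2 stands lowest of the two numbers, with compound 1 as its nearest neighbour; the one step on record, a number 13 percentage points lower from compound 1 to compound 2 (beyond the scatter), lies beyond the scatter and is modest in size. Compound 3, `O=C(COCc1c(-c2ccccc2)no[n+]1[O-])Nc1ccc(C(=O)/C=C/c2ccco2)cc1`, differs from compound 2 by furan-2-yl in place of 4-methoxyphenyl on a double-bonded chain carbon bound to a double-bonded chain carbon. Among the compounds with values here, the step from compound 1 to compound 2 touches the same place on the chain but exchanges one substituent for another on a ring that stays, whereas here the whole ring is exchanged; no measured step of that kind exists. The expectation therefore rests on a thin base and is kept close to compound 2, with no step beyond the scatter assumed. Compound 3 is expected to give about 50% in this assay, within a range from 35% to 65%, which means an expected step of a number 1 percentage points higher from compound 2 to compound 3 (within the scatter).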

Compound 3, a percentage reported as inhibition, in the whole organism at one dose (the size of the read-out at that dose, not a potency): 49%
The estimate for compound 3 lay 1 percentage points above the measured number; the range from low to high includes it.
By their numbers in this assay, from the lowest: compounds 2 and 3 (each within the scatter of the next); then compound 1.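

In this assay, going by these compounds alone, the earlier compounds showed only a substituent exchanged on a ring that stays, whereas here the whole ring on the double-bonded chain carbon is exchanged, and furan-2-yl in place of 4-methoxyphenyl gives no change at the digits printed from compound 2 to compound 3 (within the scatter) within the usual scatter. Furan-2-yl in place of 4-chlorophenyl gives a number 13 percentage points lower from compound 1 to compound 3 (beyond the scatter) and so matches in printed size the methoxy in place of chloro step, a number 13 percentage points lower from compound 1 to compound 2 (beyond the scatter), leaving compound 1 apart from both others among these three compounds. Nothing on record explains either step.

Still open, on these data alone, is whether the standing of 4-chlorophenyl at this place extends to 4-bromophenyl or 4-fluorophenyl. Also open, as far as these compounds go, is how thiophen-2-yl or a saturated ring such as cyclohexyl would read at the same place.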